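Amide side-chain exchange in a vitamin D receptor agonist series

The source may hold more compounds than are shown below. What is called first, only, known or untested is meant among the compounds shown, and "the series" means these compounds.

compound 1 `CCn1c(C(=O)NCCC(=O)OC)ccc1C(CC)(CC)c1ccc(C#CC(O)(CC)CC)c(C)c1`: > 50 nM
compound 2 `CCn1c(C(=O)NCCC(=O)O)ccc1C(CC)(CC)c1ccc(C#CC(O)(CC)CC)c(C)c1`: 293 nM
compound 3 `CCN(CC)CCNC(=O)c1cc(C(CC)(CC)c2ccc(C#CC(O)(CC)CC)c(C)c2)cn1CC`: 6.98 nM

In an assay on cells for agonist activity at vitamin D3 receptor (Homo sapiens), read by microscopy (on this read-out higher numbers stand for an effect only at larger amounts of compound and lower numbers for an effect already at smaller amounts), compound 3 gives 6.98 nM, the lowest of the two numbers shown; compound 2 gives 293 nM, a gap beyond the scatter. For compound 1 the value > 50 nM is a limit of the assay and not a number. Accordingly the step that the limit leaves unreadable from compound 1 to compound 2 cannot be sized (the limit of > 50 nM in this assay, at which 1 of the 3 values shown sits). Compound 4 `CCn1cc(C(CC)(CC)c2ccc(C#CC(O)(CC)CC)c(C)c2)cc1C(=O)N[C@H](C(=O)O)C(C)C` differs from compound 3 in one place: 1-carboxy-2-methylpropyl in place of 2-(diethylamino)ethyl on an amide-type nitrogen. Going by the values given here, no measured step covers this exchange; the only guide is compound 2, which also bears a carboxy-terminated side chain on an amide-type nitrogen and sits far above compound 3. Compound 4 is therefore expected to lose potency, with a step of a 29-fold higher number from compound 3 to compound 4 (1.46 log units; beyond the scatter). The estimate for compound 4 is 200 nM, range 40 nM to 1000 nM.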

Compound 4, half-maximal effective concentration: 12.7 nM
Compound 4: middle estimate off by 16-fold (1.20 log units), on the high side; the whole stated range lies above it.
By their numbers in this assay, from the lowest: compounds 3 and 4 (each within the scatter of the next); then compound 2.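

In this assay, 1-carboxy-2-methylpropyl in place of 2-(diethylamino)ethyl on an amide-type nitrogen gives a 1.8-fold higher number from compound 3 to compound 4 (0.26 log units; within the scatter). A carboxy-terminated side chain on this nitrogen is therefore compatible with a value within the scatter of compound 3, which compound 2 could not show, as it differs from compound 4 in more than one place. Nothing at hand gives a cause for this result.

Open, as far as these compounds go, is whether the methyl ester of this side chain, its opposite stereocentre or a primary amine on the same nitrogen would stay within that range.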